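This account rests on a few compounds, and the source may have more. Where it says the series, first, only, none or still open, it means among the compounds named here.

Four compounds share one core and differ only in the pair of groups attached to the carbon that is double-bonded to that core. Compound 1 `N#C/C(=C\c1c(-c2ccccc2)[nH]c2ccccc12)C(=O)c1ccccc1` has "not determined" (no result reported) in a functional assay on MOLT-4 cells (Homo sapiens) for inhibition, read by sulforhodamine B assay, with a stated time of 48 h (a higher number here means a weaker inhibitor of growth, a lower number a stronger inhibitor of growth), and compound 3 `O=C(/C(=C\c1c(-c2ccccc2)[nH]c2ccccc12)S(=O)(=O)c1ccccc1)c1ccccc1` likewise has "not determined" (no result reported) in this assay. For the measured compounds named here, compound 2 `CCOC(=O)C(=Cc1c(-c2ccccc2)[nH]c2ccccc12)C(=O)OCC` gives 3900 nM in this assay, and this is the only number the series holds, which leaves compound 3 without a value of its own and without a measured neighbour. Compound 4 `CC(=O)/C(=C\c1c(-c2ccccc2)[nH]c2ccccc12)S(=O)(=O)c1ccccc1` differs from compound 3 by methyl in place of phenyl on a carbonyl carbon. Going by the values given here, no measured step shows what such a change does here; the step is expected to be small, within the scatter. Anchored on compound 2 at 3900 nM, compound 4 is expected to give about 5000 nM, within a range from 800 nM to 30000 nM.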

Compound 4, concentration for 50% growth inhibition: 1600 nM
The estimate for compound 4 lay 3.1-fold (0.49 log units) above the measured number; low and high end bracket the measured number.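

Compound 3 has no single number to set against compound 4, so no step can be read from this result. As far as these compounds go, what changing benzoyl to acetyl does in this assay stays open. Nothing shown offers an explanation for the value of compound 4.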